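The source may hold more compounds than are shown below. What is called first, only, known or untested is meant among the compounds shown, and "the series" means these compounds.

Compound 2 `CCOC(=O)CCCCCOc1cccc(CN(C(=O)c2ccc(-c3ccco3)cc2)C(C)C)c1` and its close neighbour compound 1 `CCOC(=O)CCCCCOc1cccc(CN(C(=O)c2ccc(-c3cccc(C(C)=O)c3)cc2)C(C)C)c1` were both tested in an ADME assay on HepG2 cells (Homo sapiens) for cytotoxicity, read by CellTiter-Glo and resazurin assay, with a stated time of 72 h; on this read-out lower numbers stand for an effect already at smaller amounts and higher numbers for an effect only at larger amounts of compound. In this assay compound 1 gives > 26000 nM, which is a limit of the assay rather than a number. In this assay compound 2 gives > 26000 nM, again a limit and not a number. Because of the limit of > 26000 nM in this assay, at which 2 of the 2 values shown sit, the step that the two limits leave unreadable from compound 1 to compound 2 cannot be read, so compound 2 stands at the same limit as the one other compound shown, without a number of its own. Compound 3 `CCOC(=O)CCCCCOc1cccc(CN(C(=O)c2ccc(-c3cccc(-c4nnc(C)o4)c3)cc2)C(C)C)c1` differs from compound 2 by 3-(5-methyl-1,3,4-oxadiazol-2-yl)phenyl in place of furan-2-yl on an aromatic carbon. For the measured compounds named here, the only measured step, from compound 1 to compound 2, has no readable size, so nothing here suggests that compound 3 will fall into the range the assay can measure. For compound 3 the expected result in this assay is 40000 nM, with a range from 15000 nM to 120000 nM. The step that the limit leaves unreadable from compound 2 to compound 3 that this estimate means is expected to stay within the scatter.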

Compound 3, half-maximal effective concentration: > 26000 nM
Compound 3 was reported as a limit (the forecaster's own chance of this, stated with the estimate: 80%); the middle value lies beyond the limit too.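

No new step can be read between compound 1, compound 2 and compound 3, because each is reported only as a limit and not as a number: the limit of > 26000 nM in this assay, at which 3 of the 3 values shown sit.

The compounds shown leave open whether swapping these groups changes cytotoxicity at all, and at what concentration any of the three would reach its half-maximal effect.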